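The compounds below may be only part of what the source reports. "The series", "measured", "known", "first", "only" and "open" are said of these compounds alone.

Three compounds of one series have been run through an ADME assay on MT4 cells (Homo sapiens) for cytotoxicity, read by MTT assay; on this read-out lower numbers stand for higher toxicity in this test and higher numbers for lower toxicity in this test. Compound 1 `COc1cccc2c1c(C(=O)/C=C(\O)C(=O)O)cn2Cc1ccc(F)cc1F` gives 20800 nM. Compound 2 `CCOC(=O)/C(O)=C/C(=O)c1cn(Cc2ccc(F)cc2F)c2cccc(OC)c12` gives 65500 nM, and compound 3 `CCOC(=O)/C(O)=C/C(=O)c1cn(Cc2c(F)ccc(F)c2F)c2cccc(OC)c12` gives 40500 nM. Between compound 2 and compound 3 the change is 2,3,6-trifluorophenyl in place of 2,4-difluorophenyl on a saturated chain carbon bound to an aromatic nitrogen, and the step is a 1.6-fold lower number from compound 2 to compound 3 (0.21 log units; within the scatter). Between compound 2 and compound 1 the change is hydrogen in place of ethyl on an oxygen next to a carbonyl group, which made a 3.1-fold lower number from compound 2 to compound 1 (0.50 log units; beyond the scatter).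

Compound 4 `COc1cccc2c1c(C(=O)/C=C(\O)C(=O)O)cn2Cc1c(F)ccc(F)c1F` repeats that change on the core of compound 3: hydrogen in place of ethyl on an oxygen next to a carbonyl group. The place is the same word for word, so this is the same change, made twice in the set; the two cores differ in the way already given between compound 2 and compound 3.

Within the data shown here, for compound 4 in this assay a step of a 3.1-fold lower number from compound 3 to compound 4 (0.49 log units; beyond the scatter) is expected, close to the earlier one, because a 3.1-fold lower number from compound 2 to compound 1 (0.50 log units; beyond the scatter) is the only measured instance of this change and nothing in the set speaks against carrying it over. Compound 4 is therefore estimated at 13000 nM in this assay, with a range from 6000 nM to 30000 nM.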

Compound 4, half-maximal cytotoxic concentration: 49400 nM
Compound 4: the middle estimate sits 3.8-fold (0.58 log units) below what was measured; the measured number lies above the stated range.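

In this assay the change of ethyl to hydrogen on an oxygen next to a carbonyl group does not carry over from one core to the other, since on the core of compound 3 the step is a 1.2-fold higher number from compound 3 to compound 4 (0.09 log units; within the scatter), which sets it apart from the earlier step: the same change on two cores in this assay, a 3.1-fold lower number (0.50 log units; beyond the scatter) from compound 2 to compound 1 and a 1.2-fold higher number (0.09 log units; within the scatter) from compound 3 to compound 4, 3.8-fold (0.58 log units) apart, beyond the scatter of two such steps

The same four compounds, read through 2,3,6-trifluorophenyl in place of 2,4-difluorophenyl, give a 2.4-fold higher number from compound 1 to compound 4 (0.38 log units; beyond the scatter), and this too depends on the partner group: the same change on two cores in this assay, a 1.6-fold lower number (0.21 log units; within the scatter) from compound 2 to compound 3 and a 2.4-fold higher number (0.38 log units; beyond the scatter) from compound 1 to compound 4, 3.8-fold (0.58 log units) apart, beyond the scatter of two such steps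

So the two changes do not add up in this set, but a single square of four compounds shows neither the reason for this nor which of the two steps is the more usual one for the series.

Still open, as far as these compounds go, is how an amide, a methyl ester or a longer chain in place of ethyl would behave on these two cores. A third fluorinated or chlorinated benzyl group would show whether the ester-to-acid step follows either of the two seen here.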